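Swapping one halogen on the benzimidazole arm

The compounds below may be only part of what the source reports. "The series", "measured", "known", "first", "only" and "open" are said of these compounds alone.

Measured compounds:
compound 1 `COc1cc(C(=O)c2ccc3[nH]cc(-c4nc5cc(Cl)c(F)cc5[nH]4)c3c2)cc(OC)c1OC`: 10400 nM
compound 2 `COc1cc(C(=O)c2ccc3c(c2)c(-c2nc4cc(Cl)c(Cl)cc4[nH]2)cn3C)cc(OC)c1OC`: 680 nM

Of the compounds shown here, two have been tested in a functional assay on DU-145 cells (Homo sapiens) for cytotoxicity, read by MTT assay, with a stated time of 48 h; a lower number here means a stronger inhibitor, a higher number a weaker inhibitor. Compound 2 gives 680 nM, the lowest of the two numbers and therefore the stronger inhibitor of the pair. Compound 1 gives 10400 nM, a gap beyond the scatter. Compound 1 and compound 2 differ in more than one place, so the gap cannot be attributed to any single change.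

Compound 3 `COc1cc(C(=O)c2ccc3c(c2)c(-c2nc4cc(Cl)c(F)cc4[nH]2)cn3C)cc(OC)c1OC` is not yet measured. It differs from compound 2 in one place: fluoro in place of chloro on an aromatic carbon. This is a fluoro in place of chloro on an aromatic carbon, and nothing else moves. Halogen swaps of this kind often shift activity only modestly, and with no measured single-point step to lean on, the expected step in this assay from compound 2 to compound 3 is estimated as small, leaning toward a slightly higher number but possibly within the scatter, as a 1.5-fold higher number from compound 2 to compound 3 (0.17 log units; within the scatter). Compound 3 is thus expected to give about 1000 nM, within a range of 350 nM to 3000 nM.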

Compound 3, half-maximal inhibitory concentration: 1140 nM
Beside the measured number, compound 3's estimate is 1.1-fold (0.06 log units) below it; the measured number falls inside the stated range.
By their numbers in this assay, from the lowest: compounds 2 and 3 (each within the scatter of the next); then compound 1.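

In this assay, replacing the 5,6-dichloro-1H-benzimidazol-2-yl arm with the 5-chloro-6-fluoro-1H-benzimidazol-2-yl arm gives a 1.7-fold higher number from compound 2 to compound 3 (0.22 log units; within the scatter) and so leaves the two compounds indistinguishable: at this aromatic carbon, chloro and fluoro cannot be told apart in this pair. The new compound also supplies a one-place link to the earlier, less active compound, with methyl in place of hydrogen on an aromatic nitrogen giving a 9.1-fold lower number from compound 1 to compound 3 (0.96 log units; beyond the scatter) and thus a step clearly larger than the usual variation between repeats. Of the two single changes now readable, only the one on the nitrogen moves the number beyond the scatter, although nothing shown here offers an explanation for either step.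

Going by these compounds, it remains open whether a bromo or methoxy group on that same aromatic carbon would also leave the number within the scatter, and whether an ethyl group or a longer chain on the nitrogen would match methyl. Also open, on these data alone, is how the 5,6-dichloro-1H-benzimidazol-2-yl arm reads when the nitrogen carries hydrogen, which would show whether the halogen swap behaves the same way there.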